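Phenyl for Cyclohexyl: Expected Cytotoxicity of Compound 4

The source may report more compounds than this note shows. Statements on the series, on what has been measured and on what is new or still open speak of the compounds shown alone.

Three compounds share one core, shown for compound 1 as `CCC1(Cc2ccccc2)OS(=O)(=O)CC1=O`. In an ADME assay on HEL cells (Homo sapiens) for cytotoxicity, with a stated time of 3 days (on this read-out higher numbers stand for lower toxicity in this test and lower numbers for higher toxicity in this test), compound 1 gives > 100000 nM, a limit of the assay rather than a number. Compound 2, `CCC1(Cc2ccccc2)OS(=O)(=O)C=C1OCC1CCCCC1`, likewise reaches only a limit in this assay, namely >= 200000 nM. Compound 3, `C=CCOC1=CS(=O)(=O)OC1(CC)Cc1ccccc1`, gives 80000 nM in this assay, and the step of an at least 2.5-fold lower number from compound 2 to compound 3 (0.39 log units; beyond the scatter) counts as at least modest. Compound 4, `CCC1(Cc2ccccc2)OS(=O)(=O)C=C1OCc1ccccc1`, is unmeasured and differs from compound 2 by phenyl in place of cyclohexyl on a saturated chain carbon bound to an oxygen on an unsaturated carbon. Within the data shown here, the one measured step leaving compound 2 also replaces cyclohexyl and lowers the number beyond the scatter, yet compound 2 sits at the limit of >= 200000 nM in this assay, at which 1 of the 3 values shown sits, so its true value stays open. A similar or smaller move, or another limit, is expected: compound 4 is estimated at 150000 nM, within 60000 nM to 400000 nM, a step of an at least 1.3-fold lower number from compound 2 to compound 4 (0.12 log units; that floor lies within the scatter).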

Compound 4, minimum cytotoxic concentration: >= 50000 nM
Compound 4 gave a limit, no number; the forecaster's own chance of this, stated with the estimate: 60%; the middle value does not contradict the limit.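

The result for compound 4 is only a limit, so its steps from compound 2 and from compound 3 cannot be read. The compounds shown leave open how phenyl compares with cyclohexyl or vinyl here.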